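Bromo for trifluoromethyl on the benzyl ring of compound 3

The source may report more compounds than this note shows. Statements on the series, on what has been measured and on what is new or still open speak of the compounds shown alone.

Measured compounds:
- compound 1, `O=C1NCc2c(NCc3ccccc3[N+](=O)[O-])cccc21`: > 100000 nM
- compound 2, `O=[N+]([O-])c1cc(Cl)ccc1CNc1cc(C(F)(F)F)cc2[nH]ncc12`: 1700 nM
- compound 3, `FC(F)(F)c1cccc(CNc2cc(C(F)(F)F)cc3[nH]ncc23)c1`: 12200 nM

In an assay for inhibition of Tryptophan 2,3-dioxygenase (Homo sapiens), with stated times of 10 min and 60 min (on this read-out higher numbers stand for weaker inhibition and lower numbers for stronger inhibition), compound 3 gives 12200 nM. This is the highest of the two numbers reported; the nearest is compound 2, whose value of 1700 nM lies lower by a gap that is beyond the scatter. Compound 1 is reported only as a limit of the assay, > 100000 nM, and not as a number (the limit of > 100000 nM in this assay, at which 1 of the 3 values shown sits).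

Compound 4, `FC(F)(F)c1cc(NCc2cccc(Br)c2)c2cn[nH]c2c1`, has not yet been measured. It differs from compound 3 in one place: bromo in place of trifluoromethyl on an aromatic carbon, on a six-membered aromatic ring of carbon only, meta to a large group. For the measured compounds named here, no pair of measured compounds differing in this single place is available, so the size of the step cannot be read from the data. Both groups are of the halogen type and neither adds a hydrogen-bond donor or acceptor. A step of modest size is expected, in either direction, likely within or only slightly beyond the scatter.

Compound 4 is therefore estimated at 8000 nM, within 2500 nM to 30000 nM, which means an expected step of a 1.5-fold lower number from compound 3 to compound 4 (0.18 log units; within the scatter).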

Compound 4, half-maximal inhibitory concentration: 19100 nM
Beside the measured number, compound 4's estimate is 2.4-fold (0.38 log units) below it; measured number inside the range.
By their numbers in this assay, from the lowest: compound 2; then compounds 3 and 4 (each within the scatter of the next). At a limit, above all of these: compound 1.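

In this assay, bromo in place of trifluoromethyl on an aromatic carbon of a six-membered aromatic ring of carbon only, meta to a large group, gives a 1.6-fold higher number from compound 3 to compound 4 (0.19 log units; within the scatter). For the compounds shown here, this is the first step that can be read at a single place, and it shows that this read-out does not separate the two groups at this position, even though the entering bromo is one heavy atom and the leaving trifluoromethyl is four. Nothing measured here bears on the cause of this outcome.

Steps to compound 1 and compound 2 cannot be read, since each differs from compound 3 and compound 4 in more than one place, so the series does not show how this exchange would behave alongside the other features of those compounds. On these data alone, how this aromatic carbon would respond to a group of another kind, such as a methoxy, an amine or a carboxylic acid, also remains open, as both groups compared here have no hydrogen-bond donors or acceptors.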